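Capping a Hydroxy Group on a Shared Core

The compounds below may be only part of what the source reports. "The series", "measured", "known", "first", "only" and "open" are said of these compounds alone.

Two measured compounds share one core and differ only in the groups carried on one of their rings. Compound 1 `O=C(Nc1ccccc1)c1coc2ccccc2c1=O` has that ring bare; in an assay on HEK293 cells for displacement of a labelled ligand from adenosine receptor A2b (Homo sapiens), read by scintillation counting, with a stated time of 30 min (on this read-out lower numbers stand for stronger inhibition and higher numbers for weaker inhibition), compound 1 gives 8510 nM. Compound 2 `COc1ccc(NC(=O)c2coc3ccccc3c2=O)cc1O` carries a methoxy and a hydroxy group on the same ring; in this assay compound 2 gives 5820 nM. Of the two numbers shown, the one for compound 2 is the lower, yet its distance from compound 1 stays within the usual scatter of repeated measurements, so the two compounds cannot really be told apart.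

Compound 3 `COc1ccc(NC(=O)c2coc3ccccc3c2=O)cc1OC` takes one further step: methyl in place of hydrogen on an oxygen on an aromatic ring, so that the hydroxy becomes a methoxy. Within the data shown here, no measured pair in this set shows what such a change does, so nothing here points to a step in either direction; the reasonable expectation is a change no larger than the scatter itself. Compound 3 is therefore estimated at 5500 nM, with a plausible range from 1800 nM to 17000 nM. That estimate amounts to an expected step of a 1.1-fold lower number from compound 2 to compound 3 (0.02 log units; within the scatter), essentially nothing beyond the scatter.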

Compound 3, inhibition constant: 6390 nM
Compound 3: middle estimate off by 1.2-fold (0.07 log units), on the low side, within the range that was stated.
By their numbers in this assay, from the lowest: compounds 2, 3 and 1 (each within the scatter of the next).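

Putting a methyl on the oxygen, which turns the hydroxy into a methoxy, gives in this assay a 1.1-fold higher number from compound 2 to compound 3 (0.04 log units; within the scatter) and so leaves the two compounds indistinguishable. Among these compounds, this is the first measured pair in the set to isolate this change, and it shows that at this oxygen on an aromatic ring, the reading does not detectably depend on whether hydrogen or methyl is attached. Nothing available here offers a measured explanation for this outcome.

A single pair at a single position cannot show whether this tolerance extends further: an ethyl group or a longer chain on the same oxygen might give a similar number or a clearly different one, and the same is true of an amine or a carboxylic acid in place of the hydroxy. It also remains open whether the same methyl-for-hydrogen change would be equally quiet on a ring carrying other groups, since only one such surrounding is shown here.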